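The source may report more compounds than this note shows. Statements on the series, on what has been measured and on what is new or still open speak of the compounds shown alone.

In an assay on cytosol from placenta for inhibition of 17-beta-hydroxysteroid dehydrogenase type 1 (Homo sapiens), read by HPLC, with a stated time of 10 min, in the presence of a further agent that is not named here (on this read-out lower numbers stand for stronger inhibition and higher numbers for weaker inhibition), the measured compounds stand as follows:

Compound 1 `Cc1ccccc1N(C)C(=O)c1ccc(-c2ccccc2O)o1` gives 1900 nM.
Compound 2 `Cc1ccc(F)cc1N(C)C(=O)c1ccc(-c2ccc(O)cc2)o1` gives 41 nM.
Compound 3 `Cc1c(F)cccc1N(C)C(=O)c1ccc(-c2ccc(O)cc2)o1` gives 170 nM.

Compound 3 holds the second highest of the three numbers in this assay. Its nearest neighbour is compound 2, and the step between them is a 4.1-fold higher number from compound 2 to compound 3 (0.62 log units; beyond the scatter). Within the data shown here, compound 1 lies furthest from compound 3: in this assay compound 1 gives a higher number than compound 3, but compound 1 differs from the other two in more than one place, so no single step connects them.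

Compound 4 `Cc1ccncc1N(C)C(=O)c1ccc(-c2ccc(O)cc2)o1` is not yet measured. It differs from compound 3 in one place: 4-methylpyridin-3-yl in place of 3-fluoro-2-methylphenyl on an amide-type nitrogen. Among the measured compounds shown here, only the step between compound 2 and compound 3 bears on this change, since it also alters the group on the amide-type nitrogen, and that step was a 4.1-fold higher number from compound 2 to compound 3 (0.62 log units; beyond the scatter). It shows that changes to this group can shift the number in this assay beyond the scatter, but it gives no direction for a ring with a nitrogen atom in it. For the measured compounds named here, no measured compound carries a pyridinyl group, so the direction is open. The estimate therefore stays near compound 3 with a wide range: compound 4 is expected to give 120 nM in this assay, between 30 nM and 500 nM. The step that this estimate means, from compound 3 to compound 4, is expected to be a 1.4-fold lower number from compound 3 to compound 4 (0.15 log units; within the scatter).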

Compound 4, half-maximal inhibitory concentration: 260 nM
Beside the measured number, compound 4's estimate is 2.2-fold (0.34 log units) below it, within the range that was stated.
By their numbers in this assay, from the lowest: compound 2; then compounds 3 and 4 (each within the scatter of the next); then compound 1.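

In this assay, the only ring with a nitrogen atom shown on the amide-type nitrogen, 4-methylpyridin-3-yl, cannot be told apart from 3-fluoro-2-methylphenyl, as the change gives a 1.5-fold higher number from compound 3 to compound 4 (0.18 log units; within the scatter); a carbon-only ring carrying fluorine and no hydrogen-bond acceptor can thus give way to this ring with one acceptor without a change beyond the scatter. Set against 5-fluoro-2-methylphenyl, the same ring gives a 6.3-fold higher number from compound 2 to compound 4 (0.80 log units; beyond the scatter), so among compound 2, compound 3 and compound 4 the 5-fluoro-2-methylphenyl group alone stands apart, and the effect of this swap depends on which of the two fluorinated groups it replaces. The data offer no measurement that accounts for these numbers.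

As far as these compounds go, what remains open is how the number would respond to a 2-methylpyridin-3-yl group, with its ring nitrogen placed differently, or to a ring on the amide-type nitrogen carrying an amine or a carboxylic acid. From the compounds shown here alone, it is also open whether a fluorine atom added to the 4-methylpyridin-3-yl ring would bring the number closer to that of compound 2.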